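Leucine-linked pyrrolidine amides at the urotensin receptor

The source may hold more compounds than are shown below. What is called first, only, known or untested is meant among the compounds shown, and "the series" means these compounds.

Measured compounds:
compound 1, `CN(C)CCCOc1ccc(CN2CC[C@H](NC(=O)c3ccc(C#N)cc3)C2)cc1` — < 10000 nM
compound 2, `CN(C)CCCOc1ccc(CN2CC[C@H](NC(=O)c3ccco3)C2)cc1` — < 10000 nM
compound 3, `CC(C)C[C@H](NC(=O)c1ccco1)C(=O)N[C@H]1CCN(Cc2ccc(OCCCN(C)C)cc2)C1` — 631 nM

Of the compounds shown here, three have been tested in an assay on HEK293 cells for binding affinity to Urotensin-2 receptor (Homo sapiens), read by radioligand binding; on this read-out lower numbers stand for stronger inhibition and higher numbers for weaker inhibition. For compound 1 the result is a limit of the assay, < 10000 nM. For compound 2 the result is likewise a limit, < 10000 nM. Going by the values given here, compound 3 is the only one with a number, 631 nM. Among the compounds with values here, the one step among the measured compounds, a step that the two limits leave unreadable from compound 1 to compound 2, cannot be read because of the limit of < 10000 nM in this assay, at which 2 of the 3 values shown sit.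

Compound 4, `CC(=O)N[C@@H](CC(C)C)C(=O)N[C@H]1CCN(Cc2ccc(OCCCN(C)C)cc2)C1`, has not yet been tested in this assay. It differs from compound 3 by methyl in place of furan-2-yl on a carbonyl carbon. Within the data shown here, no measured step shares this change; the step from compound 1 to compound 2 also involves the furan-2-yl group, but its size is not readable. So the expectation rests on compound 3 alone, at 631 nM, with a loss of the aromatic ring. Compound 4 is therefore expected to be weaker, with the step of a 4.0-fold higher number from compound 3 to compound 4 (0.60 log units; beyond the scatter). The estimate for compound 4 is 2500 nM, between 600 nM and 9000 nM.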

Compound 4, inhibition constant: 2510 nM
The estimate for compound 4 lay 1.0-fold (0.00 log units) below the measured number; the range from low to high includes it.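

In this assay, going by these compounds alone, compound 4 gives the first readable step at this place, on a carbonyl carbon whose other neighbour is an amide-type nitrogen: a 4.0-fold higher number from compound 3 to compound 4 (0.60 log units; beyond the scatter). Exchanging furan-2-yl for methyl removes the five-membered aromatic ring and costs a modest amount of binding, yet compound 4 still gives a number rather than a limit. The steps to compound 4 from compound 1 and from compound 2 cannot be read: the limit of < 10000 nM in this assay, at which 2 of the 4 values shown sit.

The compounds shown leave open whether a phenyl, a thiophen-2-yl or a longer chain such as propyl on the same carbonyl carbon would give a number closer to that of compound 3 or to that of compound 4. They also do not separate the loss of the ring from the loss of its oxygen atom.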